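A methyl on the fused ring: from compound 2 to compound 4

This account rests on a few compounds, and the source may have more. Where it says the series, first, only, none or still open, it means among the compounds named here.

Compound 1 `CCn1c(=O)/c(=C2\Sc3ccc(C)cc3N2C)s/c1=C\c1ccncc1Nc1ccccc1Cl`: 350 nM
Compound 2 `CCn1c(=O)/c(=C2\Sc3ccccc3N2C)s/c1=C\c1ccncc1Nc1ccccc1C`: 470 nM
Compound 3 `CCn1c(=O)/c(=C2\Sc3ccccc3N2C)s/c1=C\c1ccncc1Nc1ccccc1Cl`: 460 nM

Of the compounds shown here, three have been measured in a functional assay on CWR22R cells (Homo sapiens) for inhibition; a lower number here means a stronger inhibitor, a higher number a weaker inhibitor. Compound 2 gives the highest of the three numbers, yet its gap to compound 3 a 1.0-fold lower number from compound 2 to compound 3 (0.01 log units; within the scatter) and its gap to compound 1 are both within the scatter, so no order among them can be claimed. Compound 4 `CCn1c(=O)/c(=C2\Sc3ccc(C)cc3N2C)s/c1=C\c1ccncc1Nc1ccccc1C` differs from compound 2 by methyl in place of hydrogen on an aromatic carbon. The same change, read in reverse, separates compound 3 from compound 1: a 1.3-fold higher number from compound 1 to compound 3 (0.12 log units; within the scatter), within the scatter. The expected step in this assay a 1.3-fold lower number from compound 2 to compound 4 (0.12 log units; within the scatter) is therefore small, toward a lower number but not beyond the scatter. For compound 4 the estimate is 360 nM, with a range from 180 nM to 720 nM.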

Compound 4, half-maximal inhibitory concentration: 480 nM
Compound 4: the middle estimate sits 1.3-fold (0.12 log units) below what was measured, within the range that was stated.
By their numbers in this assay, from the lowest: compounds 1, 3, 2 and 4 (each within the scatter of the next).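

In this assay, methyl in place of hydrogen on an aromatic carbon gives a 1.0-fold higher number from compound 2 to compound 4 (0.01 log units; within the scatter), and methyl in place of chloro on the other aromatic ring gives a 1.4-fold higher number from compound 1 to compound 4 (0.14 log units; within the scatter). The methyl change can now be read on two cores, and neither step nor the gap between them goes beyond the scatter: the same change on two cores in this assay, a 1.3-fold higher number (0.12 log units; within the scatter) from compound 1 to compound 3 and a 1.0-fold lower number (0.01 log units; within the scatter) from compound 4 to compound 2, 1.3-fold (0.13 log units) apart, within the scatter of two such steps
The exchange of chloro and methyl also reads alike on both cores: the same change on two cores in this assay, a 1.0-fold lower number (0.01 log units; within the scatter) from compound 2 to compound 3 and a 1.4-fold lower number (0.14 log units; within the scatter) from compound 4 to compound 1, 1.3-fold (0.13 log units) apart, within the scatter of two such steps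
From the compounds shown here alone, whether a methoxy, an amine or a carboxylic acid on that same aromatic carbon would shift the number beyond the scatter remains open.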